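Furan-2-yl Ketone on the Quinoline Enone Series

The source may hold more compounds than are shown below. What is called first, only, known or untested is meant among the compounds shown, and "the series" means these compounds.

Measured compounds:
Compound 1 `COc1ccc(-c2cc3ccccc3nc2/C=C/C(=O)c2c(OC)cccc2OC)cc1` gives 4710 nM in a functional assay on NCI-H1299 cells (Homo sapiens) for antiproliferative activity, read by XTT assay, with a stated time of 72 h; on this read-out higher numbers stand for weaker inhibition and lower numbers for stronger inhibition.
Compound 2 `COc1ccc(-c2cc3ccccc3nc2/C=C/C(=O)c2ccc([N+](=O)[O-])cc2)cc1` gives 770 nM in this assay.

Going by the values given here, compound 2 stands as the lowest of the two numbers in this assay; its nearest neighbour is compound 1, and the one step measured so far, a 6.1-fold lower number from compound 1 to compound 2 (0.79 log units; beyond the scatter), separates them, beyond the scatter. Compound 3 `COc1ccc(-c2cc3ccccc3nc2/C=C/C(=O)c2ccco2)cc1` is not yet measured. It differs from compound 2 in one place: furan-2-yl in place of 4-nitrophenyl on a carbonyl carbon.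

Among the compounds with values here, only the step from compound 1 to compound 2 bears on this change, and it concerns a different exchange on the same carbonyl carbon, so it gives no direct guide to the furan-2-yl group. The data show that the group on the carbonyl carbon can move the number by a modest amount, and compound 2 already holds the lowest value. Compound 3 is therefore expected to give a somewhat higher number than compound 2 in this assay, a step of a 2.1-fold higher number from compound 2 to compound 3 (0.32 log units; beyond the scatter). The estimate for compound 3 is 1600 nM, within a range from 500 nM to 5000 nM.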

Compound 3, half-maximal inhibitory concentration: 730 nM
Estimate against measurement, compound 3: 2.2-fold (0.34 log units) above; low and high end bracket the measured number.
By their numbers in this assay, from the lowest: compounds 3 and 2 (each within the scatter of the next); then compound 1.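

On the carbonyl carbon, furan-2-yl and 4-nitrophenyl cannot be told apart in this assay (a 1.1-fold lower number from compound 2 to compound 3 (0.02 log units; within the scatter)), although the group that enters is a five-membered aromatic ring with 1 hetero atom and 5 heavy atoms, while the one that leaves is a six-membered aromatic ring of carbon only with 9 heavy atoms. The exchange of 2,6-dimethoxyphenyl for furan-2-yl (a 6.5-fold lower number from compound 1 to compound 3 (0.81 log units; beyond the scatter)) now stands alongside the exchange for 4-nitrophenyl (a 6.1-fold lower number from compound 1 to compound 2 (0.79 log units; beyond the scatter)), so two quite different groups on this carbon, one of them without any nitro group, each separate from compound 1 by a step beyond the scatter. Nothing available explains why these two groups read alike or why compound 1 stands apart from both.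

The compounds shown leave open whether this level depends on an aromatic ring on the carbonyl carbon at all, since a piperidine, a simple methyl group or a longer alkyl chain could be placed there. They also leave open how other five-membered rings, such as thiophene or pyrrole, would compare with furan-2-yl on the same shared core.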